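A few compounds are considered here, and "the series" means these few. Any claim that something is new, unique, unknown or untested is made for them only; others in the source may bear on it.

Working notes on the series in an assay for inhibition of RAC-alpha serine/threonine-protein kinase (Homo sapiens), read by HTRF, with a stated time of 1 h; a higher number here means a weaker inhibitor, a lower number a stronger inhibitor.

Of the compounds shown here, three have numbers so far. Compound 1, `CNC(=O)C[C@@H]1C[C@@H](c2ccc(Cl)c(Cl)c2)[C@H](NC(=O)c2cc(-c3c(Cl)cnn3C)c(Cl)o2)CN1`, gives 2.64 nM in this assay, the lowest of the three. Compound 2, `Cn1ncc(Cl)c1-c1cc(C(=O)NC2CNCCC2c2ccc(C(F)(F)F)cc2)oc1Cl`, gives 7.2 nM in this assay; the gap from compound 1 to compound 2 is beyond the scatter. Compound 3, `Cn1ncc(Cl)c1-c1cc(C(=O)NC2CNCC2c2ccc(C(F)(F)F)cc2)oc1Cl`, gives 538 nM in this assay, the highest number of the three and far beyond the scatter from compound 1. For the measured compounds named here, compounds 2 and 3 share the shared core and amide with compound 1 but differ from it in more than one place, so no single step between them is set out.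

Compound 4, `Cn1ncc(Cl)c1-c1cc(C(=O)N[C@@H]2CN[C@H](CCN3CCC(O)CC3)C[C@H]2c2ccc(Cl)c(Cl)c2)oc1Cl`, is not yet measured. It differs from compound 1 in one place: (4-hydroxypiperidin-1-yl)methyl in place of methylcarbamoyl on a saturated chain carbon bound to a saturated ring carbon. Going by the values given here, no pair of measured compounds shows this change, so its effect has to be estimated rather than read off. Both groups carry a hydrogen-bond donor, and the rest of compound 4 is unchanged from compound 1, so the step is expected to be small, at most a modest move toward a higher number.

Compound 4 is estimated at 4 nM in this assay, within 1.2 nM to 15 nM, which would mean an expected step of a 1.5-fold higher number from compound 1 to compound 4 (0.18 log units; within the scatter).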

Compound 4, half-maximal inhibitory concentration: 5.99 nM
For compound 4 the middle estimate is 1.5-fold (0.18 log units) below the measured one, within the range that was stated.
By their numbers in this assay, from the lowest: compound 1; then compounds 4 and 2 (each within the scatter of the next); then compound 3.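

In this assay, for the compounds shown here, (4-hydroxypiperidin-1-yl)methyl in place of methylcarbamoyl on a saturated chain carbon bound to a saturated ring carbon gives a 2.3-fold higher number from compound 1 to compound 4 (0.36 log units; beyond the scatter), a modest step and the first single-place comparison. The position therefore takes a group with 8 heavy atoms and a six-membered non-aromatic ring in place of one with 4 heavy atoms and no ring, and compound 4 still reads 5.99 nM in the single-digit nanomolar range of the series. No supporting measurement accounts for the size of this step, so the result stands as a bare comparison of two structures.

From the compounds shown here alone, the contribution of the hydroxyl remains open, since a plain piperidin-1-yl group at this place would be needed to separate it from the ring, and a morpholin-4-yl group would test a different ring hetero atom. Also open, going by these compounds, is how far the position tolerates other kinds of group, such as a carboxylic acid, a dimethylamino group or a longer chain carrying the same hydroxypiperidine.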